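The source may report more compounds than this note shows. Statements on the series, on what has been measured and on what is new or still open speak of the compounds shown alone.

In a functional assay on Jurkat cells for inhibition of nuclear factor NF-kappa-B complex (Homo sapiens) (on this read-out higher numbers stand for weaker inhibition and lower numbers for stronger inhibition), compound 2 `CCOC(=O)c1cnc(-c2csc(C)n2)nc1NN1C(=O)C=C(C)C1=O` gives 8000 nM, the highest of the three numbers; compound 3 `CCOC(=O)c1cnc(-c2cccc(OC)c2)nc1NN1C(=O)C=C(C)C1=O` gives 5000 nM, and the two lie within the scatter of each other, while compound 1 `CCOC(=O)c1cnc(-c2cccs2)nc1NN1C(=O)C=C(C)C1=O` gives 20 nM with a step of a 400-fold higher number from compound 1 to compound 2 (2.60 log units; beyond the scatter). Compound 4 `CCOC(=O)c1cnc(S(=O)(=O)c2ccccc2)nc1NN1C(=O)C=C(C)C1=O` differs from compound 2 by phenylsulfonyl in place of 2-methyl-1,3-thiazol-4-yl on an aromatic carbon. The steps of a 400-fold higher number from compound 1 to compound 2 (2.60 log units; beyond the scatter) and a 250-fold higher number from compound 1 to compound 3 (2.40 log units; beyond the scatter) show that replacing thiophen-2-yl cost a great deal, and that 2-methyl-1,3-thiazol-4-yl and 3-methoxyphenyl ended within the scatter of each other. Phenylsulfonyl has no measured counterpart, so compound 4 is expected to stay close to compound 2, with a 1.3-fold higher number from compound 2 to compound 4 (0.10 log units; within the scatter) as the expected step. Compound 4 is thus estimated at 10000 nM, between 2000 nM and 50000 nM.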

Compound 4, half-maximal inhibitory concentration: 10000 nM
Compound 4: middle estimate and measured number agree at the digits printed; the measured number falls inside the stated range.
By their numbers in this assay, from the lowest: compound 1; then compounds 3, 2 and 4 (each within the scatter of the next).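

At this place between two ring nitrogen atoms, phenylsulfonyl, where a sulfonyl group rather than a ring is joined to the core, ends level with the other two replacements of thiophen-2-yl (a 1.3-fold higher number from compound 2 to compound 4 (0.10 log units; within the scatter); a 2.0-fold higher number from compound 3 to compound 4 (0.30 log units; within the scatter)). Among these four compounds, only thiophen-2-yl stands apart (a 500-fold higher number from compound 1 to compound 4 (2.70 log units; beyond the scatter)). Nothing measured here explains why thiophen-2-yl differs from the other three groups. Still open, going by these compounds, is whether furan-2-yl, another small five-membered ring, would match thiophen-2-yl. Whether an amine at this place would do so is also unknown.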